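Chain shortening in the amino-tetrahydrofuran alkylamine series

A few compounds are considered here, and "the series" means these few. Any claim that something is new, unique, unknown or untested is made for them only; others in the source may bear on it.

Among the compounds with values here, compound 1 `CCCCCCCCCCCCNC[C@@H]1OC[C@H](N)[C@H]1O` is the only member of the series for which a functional assay on MCF7 cells (Homo sapiens) for antiproliferative activity, read by MTT assay, with a stated time of 72 h (a higher number here means a weaker inhibitor, a lower number a stronger inhibitor), returns a number: compound 1 gives 12600 nM. Compound 2 `CCCCCCCCNC[C@@H]1OC[C@H](N)[C@H]1O` reaches only a limit of this assay, and in this assay compound 2 is recorded as > 128000 nM. Within the data shown here, the one measured step in the set, an at least 10-fold higher number from compound 1 to compound 2 (1.00 log units; beyond the scatter), is set by the limit (the limit of > 128000 nM in this assay, at which 1 of the 2 values shown sits), so its true size is not known, only that it is at least this large.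

Compound 3 `CCCCCCCCCCNC[C@@H]1OC[C@H](N)[C@H]1O` is not yet measured. It differs from compound 1 by hydrogen in place of ethyl on a saturated chain carbon, ten or more bonds along the chain from an amine nitrogen. This is the same kind of change as the measured step, but cut one bond further out: the chain is shortened by less than in compound 2. Since the loss of the longer piece on the way to compound 2 gave at least a modest rise in the number, a smaller loss is expected to give a smaller rise in this assay, most likely still beyond the scatter but short of the limit. The expected step is a 3.2-fold higher number from compound 1 to compound 3 (0.50 log units; beyond the scatter). Compound 3 is therefore estimated at 40000 nM, with a range from 15000 nM to 120000 nM.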

Compound 3, half-maximal inhibitory concentration: 42700 nM
Estimate against measurement, compound 3: 1.1-fold (0.03 log units) below, within the range that was stated.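

In this assay, hydrogen in place of ethyl on a saturated chain carbon, ten or more bonds along the chain from an amine nitrogen, gives a 3.4-fold higher number from compound 1 to compound 3 (0.53 log units; beyond the scatter), so the loss of the shorter piece already moves the number beyond the scatter and the fall in activity does not appear only at the chain of compound 2. Ethyl in place of hydrogen on a saturated chain carbon, eight bonds along the chain from an amine nitrogen, gives an at least 2.9-fold lower number from compound 2 to compound 3 (0.47 log units; beyond the scatter), which places the chain of compound 3 on a graded order across the three compounds, with none going against it. The size of this last step stays unknown, as the value of compound 2 is a limit: the limit of > 128000 nM in this assay, at which 1 of the 3 values shown sits.

From the compounds shown here alone, whether a chain longer than that of compound 1 lowers the number further, or whether the order turns at some length, remains open. Also open, going by these compounds, is how the series reads with a phenyl group in the chain, or with an acetamide in place of the free amine on the shared core.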